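The source may report more compounds than this note shows. Statements on the series, on what has been measured and on what is new or still open speak of the compounds shown alone.

Compound 1 `O=C(Nc1ccccc1)c1cccc(Br)c1` is a simple amide with a bromo group on one ring. In an assay on isolated protein for inhibition of thiosulfate sulfurtransferase (Homo sapiens), with a stated time of 60 min, in the absence of a further agent (on this read-out lower numbers stand for stronger inhibition and higher numbers for weaker inhibition), compound 1 reaches only the limit of the assay, reported as > 100000 nM. Compound 2 `O=C(Nc1cccc(Cl)c1)c1cccc(Br)c1` carries an added chloro group on the other ring. In this assay compound 2 likewise stops at the limit, reported as > 100000 nM. The step that the two limits leave unreadable from compound 1 to compound 2 therefore cannot be read in size or direction, since both values sit at the limit of > 100000 nM in this assay, at which 2 of the 2 values shown sit. So compound 2 stands only at a limit, with no number of its own. Compound 3 `COc1c(Br)cccc1C(=O)Nc1cccc(Cl)c1` differs from compound 2 by methoxy in place of hydrogen on an aromatic carbon. Among the compounds with values here, no measured step bears on this change, and the one step available is unreadable. Compound 3 is therefore expected to stay near the limit, with an estimated change of a step that the limit leaves unreadable from compound 2 to compound 3. The estimate for compound 3 is 150000 nM, within a range from 30000 nM to 1000000 nM.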

Compound 3, half-maximal inhibitory concentration: > 100000 nM
Compound 3 ended at the assay's limit; the forecaster's own chance of this, stated with the estimate: 75%; the middle value is on the limit's open side.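

Within the data shown here, compound 2 and compound 3 both stop at a limit, so no step between them can be read in this assay: the limit of > 100000 nM in this assay, at which 3 of the 3 values shown sit. The compounds shown leave open whether the chloro or methoxy group has any effect on inhibition, and whether any change to the shared core gives a readable value.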